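The source may report more compounds than this note shows. Statements on the series, on what has been measured and on what is new or still open speak of the compounds shown alone.

Measured compounds:
Compound 1, `CC(C)c1ccc(C(=O)CC(SCC(=O)O)C(=O)O)cc1`, 3330 nM
Compound 2, `CCCCc1ccc(C(=O)CC(SCC(=O)O)C(=O)O)cc1`, 1910 nM
Compound 3, `O=C(O)CSC(CC(=O)c1ccc(Cl)cc1)C(=O)O`, 17300 nM

Of the compounds shown here, three sharing one core have been tested in a functional assay on HeLa cells (Homo sapiens); on this read-out lower numbers stand for stronger inhibition and higher numbers for weaker inhibition. Compound 1 gives 3330 nM and stands second highest of the three numbers. Its nearest neighbour is compound 2, where a 1.7-fold lower number from compound 1 to compound 2 (0.24 log units; within the scatter), a step that stays within the scatter. Its furthest is compound 3, where a 5.2-fold higher number from compound 1 to compound 3 (0.72 log units; beyond the scatter). The pair of compounds 2 and 3 shows the same tendency, with a 9.1-fold higher number from compound 2 to compound 3 (0.96 log units; beyond the scatter).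

Compound 4, `CC(C)c1ccc(C(=O)CC(SCC(=O)O)C(=O)O)c(C(C)C)c1`, has not yet been measured in this assay. It differs from compound 1 by isopropyl in place of hydrogen on an aromatic carbon, the new group sitting on an aromatic carbon of the six-membered aromatic ring of carbon only, ortho to a large group and meta to an isopropyl group. Going by the values given here, none of the measured steps changes that position; all three compare groups at the place held by the isopropyl group of compound 1. What they do show is that exchanging one hydrocarbon group for another at that place moved the number little, while chloro raised it clearly. For compound 4 the step of a 1.3-fold lower number from compound 1 to compound 4 (0.12 log units; within the scatter) is therefore expected to be small, most likely within the scatter, with the direction uncertain. Compound 4 is estimated at 2500 nM, with a range from 800 nM to 8000 nM.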

Compound 4, half-maximal inhibitory concentration: 1100 nM
For compound 4 the middle estimate is 2.3-fold (0.36 log units) above the measured one, and the stated range covers the measured number.
By their numbers in this assay, from the lowest: compounds 4, 2 and 1 (each within the scatter of the next, the first and the last beyond it); then compound 3.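

In this assay, isopropyl in place of hydrogen on this aromatic carbon, ortho to a large group and meta to an isopropyl group, gave a 3.0-fold lower number from compound 1 to compound 4 (0.48 log units; beyond the scatter). The earlier steps shown here compared groups only at the place held by the isopropyl group of compound 1, so they said nothing about this second place on the ring. The result shows that this place also responds to substitution, and that adding a group of three carbons with no hydrogen-bond donors or acceptors here lowered the number rather than raising it, although nothing shown here explains this change.

The compounds shown leave open whether this gain belongs to isopropyl in particular or would also appear with a smaller or different group on the same carbon, such as a methyl group, a methoxy group or an amine. They also leave open whether the same addition would lower the number to a similar extent on the butyl group's core in compound 2 or the chloro group's core in compound 3.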